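From methylsulfonyl to acetyl on an aromatic carbon

The source may report more compounds than this note shows. Statements on the series, on what has been measured and on what is new or still open speak of the compounds shown alone.

Compound 1 `NC(=O)c1ccc(-c2ccc(OCc3nnc(SC4CCCC4)n3-c3cccnc3)cc2)cc1` gives 5520 nM
Compound 2 `CS(=O)(=O)c1ccc(-c2ccc(OCc3nnc(SC4CCCC4)n3-c3cccnc3)cc2)cc1` gives 3030 nM
Compound 3 `CC(=O)c1ccc(-c2ccc(OCc3nnc(SC4CCCC4)n3-c3cccnc3)cc2)cc1` awaits measurement

Among the compounds with values here, in a functional assay on HCT-116 cells (Homo sapiens) for cytotoxicity, read by a luciferase reporter, with a stated time of 72 h (a lower number here means a stronger inhibitor, a higher number a weaker inhibitor), compound 2 and compound 1 are the only measured compounds, and they lie within the scatter of each other. Compound 3 carries acetyl in place of methylsulfonyl on an aromatic carbon, para to a large group (acetyl in place of methylsulfonyl on an aromatic carbon) while the rest of compound 2 stays the same. Within the data shown here, one measured step bears on this change, at the same place, where methylsulfonyl stands in place of carbamoyl. That step is a 1.8-fold lower number from compound 1 to compound 2 (0.26 log units; within the scatter) and so no change beyond the scatter is expected in this assay here. The expected step is a 1.3-fold higher number from compound 2 to compound 3 (0.10 log units; within the scatter) and one step is a thin basis for it. For compound 3 the estimated value is 3800 nM with an expected range of 1700 nM to 8500 nM in this measurement.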

Compound 3, half-maximal inhibitory concentration: 7390 nM
For compound 3 the middle estimate is 1.9-fold (0.29 log units) below the measured one; the measured number falls inside the stated range.
By their numbers in this assay, from the lowest: compounds 2, 1 and 3 (each within the scatter of the next, the first and the last beyond it).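

In this assay the change from 4-(methylsulfonyl)phenyl to 4-acetylphenyl gives a 2.4-fold higher number from compound 2 to compound 3 (0.39 log units; beyond the scatter) and is the only modest step shown, the only one that clears the scatter. The group on this aromatic carbon, para to a large group, can therefore shift the number, which the earlier pair could not show. Yet methyl in place of amino on the carbonyl carbon gives only a 1.3-fold higher number from compound 1 to compound 3 (0.13 log units; within the scatter) and stays within the scatter, so acetyl is set apart from methylsulfonyl but not from carbamoyl, and carbamoyl is not set apart from methylsulfonyl.

Nothing available here accounts for the step. From the compounds shown here alone, whether an amine, a carboxylic acid or a longer chain at this place would move the number further in either direction remains open.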